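The source may hold more compounds than are shown below. What is called first, only, known or untested is meant among the compounds shown, and "the series" means these compounds.

Compound 1 `Cc1cc(-c2ccccc2)cc(C)c1S(=O)(=O)[C@@H](CNC(=O)C1=NOC2(CCC(CNc3ncc[nH]3)CC2)C1)C(=O)O`: 670 nM
Compound 2 `Cc1cc(C)c(S(=O)(=O)N[C@@H](CNC(=O)C2=NO[C@]3(C2)C[C@@H](CNC2N=CC=N2)N(C(=O)OCc2ccccc2)C3)C(=O)O)c(C)c1`: 13 nM

Of the two numbers shown in a functional assay for antagonist activity at integrin alpha-5/beta-1 (Homo sapiens), read by ELISA (on this read-out higher numbers stand for weaker inhibition and lower numbers for stronger inhibition), compound 1 gives the higher one, 670 nM, while compound 2 gives 13 nM, a gap well beyond the scatter. These two compounds differ in several places, so their gap cannot be tied to a single change. Compound 3 `Cc1cccc(C)c1S(=O)(=O)[C@@H](CNC(=O)C1=NOC2(CCC(CNc3ncc[nH]3)CC2)C1)C(=O)O` differs from compound 1 in one place only: hydrogen in place of phenyl on an aromatic carbon. Within the data shown here, no measured pair shows this change on its own. Removing a whole ring while leaving the rest of compound 1 unchanged is expected to weaken inhibition somewhat, an estimated step of a 2.2-fold higher number from compound 1 to compound 3 (0.35 log units; beyond the scatter). Compound 3 is therefore expected to come out near 1500 nM, in a range from 500 nM to 5000 nM.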

Compound 3, half-maximal inhibitory concentration: 1800 nM
For compound 3 the middle estimate is 1.2-fold (0.08 log units) below the measured one, and the stated range covers the measured number.
By their numbers in this assay, from the lowest: compound 2; then compound 1; then compound 3.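

Replacing phenyl with hydrogen on this aromatic carbon, para to a large group, gives a 2.7-fold higher number from compound 1 to compound 3 (0.43 log units; beyond the scatter) in this assay. The position therefore accepts a whole ring, and the phenyl goes with modestly stronger inhibition, although compound 3 without it still gives a measurable 1800 nM. No measurement shown explains this step.

Still open, from the compounds shown here alone, is whether something smaller than phenyl, such as a methoxy group or a chlorine atom, would do as well at this carbon. A ring carrying an amine in place of the plain phenyl is equally unresolved.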